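The source may report more compounds than this note shows. Statements on the series, on what has been measured and on what is new or still open speak of the compounds shown alone.

Measured in an ADME assay on the whole organism (Rattus norvegicus, strain Sprague-Dawley) for pharmacokinetics (a lower number here means slower removal, a higher number faster removal of the compound), so far:
- compound 1 `NC(=O)c1cc(-c2ccccc2)cc2c(C3CCN(S(=O)(=O)CCCN4CCCC4)CC3)c[nH]c12` gives 4 mL/min/kg
- compound 2 `NC(=O)c1cc(-c2ccccc2)cc2c(C3CCS(=O)(=O)CC3)c[nH]c12` gives 35 mL/min/kg
- compound 3 `CCS(=O)(=O)N1CCC(c2c[nH]c3c(C(N)=O)cc(-c4ccccc4)cc23)CC1` gives 16 mL/min/kg

Compound 2 has the highest number of the three. Compound 3 is its nearest neighbour and compound 1 its furthest, and both lie lower, beyond the scatter.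

The next compound, compound 4 `NC(=O)c1cc(-c2ccc(F)cc2)cc2c(C3CCS(=O)(=O)CC3)c[nH]c12`, differs from compound 2 in one place, phenyl to 4-fluorophenyl: fluoro in place of hydrogen on an aromatic carbon.

Going by the values given here, only one measured step links compounds that differ in one place: a 4.0-fold higher number from compound 1 to compound 3 (0.60 log units; beyond the scatter). It is modest and puts hydrogen in place of (pyrrolidin-1-yl)methyl on a saturated chain carbon, not fluoro on an aromatic carbon. Among the compounds with values here, no measured compound carries fluoro, so that step sets no direction and gives only a rough idea of how far one change can move the number. For this change, a small shift that stays inside the scatter is the working expectation, and a clear move either way cannot be excluded. The expected step is a 1.2-fold lower number from compound 2 to compound 4 (0.07 log units; within the scatter), which is no more than an estimate. In this assay compound 4 is estimated at 30 mL/min/kg, with an expected range of 16 mL/min/kg to 52 mL/min/kg.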

Compound 4, clearance: 23.5 mL/min/kg
For compound 4 the middle estimate is 1.3-fold (0.11 log units) above the measured one; the range from low to high includes it.
By their numbers in this assay, from the lowest: compound 1; then compounds 3, 4 and 2 (each within the scatter of the next, the first and the last beyond it).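

In this assay, fluoro in place of hydrogen on an aromatic carbon, para to a large group, gives a 1.5-fold lower number from compound 2 to compound 4 (0.17 log units; within the scatter), so at this place on the ring of carbon only, the change from phenyl to 4-fluorophenyl leaves compound 2 and compound 4 indistinguishable. Going by these compounds alone, this is the first reading at this position, and it differs in kind from the only earlier single-place step, a 4.0-fold higher number from compound 1 to compound 3 (0.60 log units; beyond the scatter), which concerns a chain on a sulfonyl sulfur and lies beyond the scatter. No supporting measurement bears on why fluoro has so little visible effect here.

The compounds shown leave open whether a larger or different group at this same place, such as chloro, methoxy, nitrile or an amine, would stay within the scatter as fluoro does, and whether fluoro on another aromatic carbon of that ring would behave alike. They also leave open whether the 4-fluorophenyl change reads the same when paired with the sulfonyl chains of compound 1 and compound 3 rather than with the group carried by compound 2.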